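Fluoro in place of hydrogen on a diaryl ether azetidine

The source may hold more compounds than are shown below. What is called first, only, known or untested is meant among the compounds shown, and "the series" means these compounds.

Going by the values given here, compound 3 `c1ccc(Oc2ccccc2OC2CNC2)cc1` is the only member of this small series with a finite number in an assay on isolated protein for displacement of a labelled ligand from sodium-dependent dopamine transporter (Homo sapiens), read by scintillation proximity assay; a lower number here means a stronger inhibitor, a higher number a weaker inhibitor: in that assay compound 3 gives 2090 nM. Compound 1 `Cc1cccc(F)c1Oc1cccc(F)c1OC1CNC1` returns a limit in this assay, > 6460 nM. Compound 2 `Fc1ccccc1Oc1cccc(F)c1OC1CNC1` likewise returns a limit, > 4860 nM. Among the compounds with values here, the one measured step, a step that the two limits leave unreadable from compound 1 to compound 2, is hydrogen in place of methyl on an aromatic carbon, and it cannot be read because the limit of > 4860 nM in this assay, at which 1 of the 3 values shown sits, and the limit of > 6460 nM in this assay, at which 1 of the 3 values shown sits, both stand at limits rather than numbers.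

Compound 4 `Fc1ccccc1Oc1ccccc1OC1CNC1` differs from compound 3 by fluoro in place of hydrogen on an aromatic carbon, on an aromatic carbon of a six-membered aromatic ring of carbon only, ortho to a large group. Within the data shown here, no measured step bears on this exact change; compound 2 carries the same fluoro together with a second one and sits at a limit, which gives only weak guidance. He therefore expects at most a modest step, a 1.4-fold higher number from compound 3 to compound 4 (0.16 log units; within the scatter), toward a weaker compound, or none beyond the scatter. His estimate for compound 4 in this assay is 3000 nM, expected to fall between 1000 nM and 9000 nM.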

Compound 4, inhibition constant: 2040 nM
Beside the measured number, compound 4's estimate is 1.5-fold (0.17 log units) above it; the range from low to high includes it.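

In this assay, fluoro in place of hydrogen on an aromatic carbon, ortho to a large group, can now be read on its own, and it gives a 1.0-fold lower number from compound 3 to compound 4 (0.01 log units; within the scatter), so at this position the change leaves the number inside the scatter. Removing the further fluoro that compound 2 carries gives an at least 2.3-fold lower number from compound 2 to compound 4 (0.37 log units; beyond the scatter), which places the weaker reading of compound 2 with that further fluoro and not with the fluoro shared by compound 2 and compound 4. From the compounds shown here alone, the true size of this second step stays unknown because compound 2 stands at a limit and not at a number: the limit of > 4860 nM in this assay, at which 1 of the 4 values shown sits.

Going by these compounds, the step between compound 1 and compound 2 cannot be read, and what the methyl of compound 1 contributes stays unknown, because compound 1 also stands at a limit: the limit of > 6460 nM in this assay, at which 1 of the 4 values shown sits. On these data alone, whether a larger group at the same position, such as chloro, methoxy or trifluoromethyl, would also leave the number inside the scatter remains open, as does the effect of the further fluoro of compound 2 when it is measured as a finite number.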